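Methoxy for fluoro on a sulfonyl-bearing ring

This account rests on a few compounds, and the source may have more. Where it says the series, first, only, none or still open, it means among the compounds named here.

Measured compounds:
Compound 1, `COc1ccc(-c2c(S(=O)(=O)c3ccc(F)cc3)cnc3cc(F)ccc23)cc1`: in an ADME assay on microsomes from liver (Homo sapiens) for metabolic stability, tested at 2.5 uM (a higher number here means faster removal of the compound, a lower number slower removal), compound 1 gives 1.77 mL/min.
Compound 2, `COc1cccc(-c2c(S(=O)(=O)c3ccc(F)cc3)cnc3c(F)cccc23)c1`: in this assay compound 2 gives 2.23 mL/min.
Compound 3, `O=S(=O)(c1ccc(F)cc1)c1cnc2cc(F)ccc2c1-c1ccc(F)cc1`: in this assay compound 3 gives 1.34 mL/min.

These three values lie close together. Compound 2 has the highest number of the three, yet its gap to compound 1 and its gap to compound 3 are both within the scatter, so no order among them can be read.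

Among the compounds with values here, the one change seen twice within this set is that from compound 3 to compound 1, described as methoxy in place of fluoro on an aromatic carbon. Its measured step is a 1.3-fold higher number from compound 3 to compound 1 (0.12 log units; within the scatter), a step the scatter of the method can account for on its own.

Compound 4, `COc1ccc(S(=O)(=O)c2cnc3c(F)cccc3c2-c2cccc(OC)c2)cc1`, is not yet measured. It is made from compound 2 by methoxy in place of fluoro on an aromatic carbon, the same change, at the same kind of place, as that from compound 3 to compound 1. The difference between the core of compound 2 and the core of compound 3 is not broken down here.

The expectation for compound 4 therefore rests on one observed pair. Because a 1.3-fold higher number from compound 3 to compound 1 (0.12 log units; within the scatter) was small, the step is expected to be a 1.3-fold higher number from compound 2 to compound 4 (0.11 log units; within the scatter), of about the same size and sign. Compound 4 is thus estimated at 2.9 mL/min, with the range expected to run from 1.5 mL/min to 5.5 mL/min, the width reflecting that a single precedent of a change within the scatter gives little to lean on.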

Compound 4, intrinsic clearance in a liver preparation (reported as CLH), per the amount of preparation that the assay uses: 2.87 mL/min
Compound 4: the middle estimate sits 1.0-fold (0.00 log units) above what was measured, within the range that was stated.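

The new pair gives a second reading of the change from 4-fluorophenyl to 4-methoxyphenyl in this assay, a 1.3-fold higher number from compound 2 to compound 4 (0.11 log units; within the scatter), and it agrees closely with the first reading: the same change on two cores in this assay, a 1.3-fold higher number (0.12 log units; within the scatter) from compound 3 to compound 1 and a 1.3-fold higher number (0.11 log units; within the scatter) from compound 2 to compound 4, 1.0-fold (0.01 log units) apart, within the scatter of two such steps. Across these two cores, then, the step carried over with the same sign and nearly the same size, and on both it stayed small enough for the scatter of the method to account for it alone. This does not show that methoxy in place of fluoro truly raises the number, since neither step can be told from repeat scatter, and two pairs cannot establish that the step would hold on any core beyond those of compound 1 and compound 4.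

The compounds shown leave open whether any replacement at this place would give a step that stands clear of the scatter, since only fluoro and methoxy appear there, and an amine, a carboxylic acid or a longer alkoxy chain such as ethoxy is not among them. Within the data shown here, they also leave open how much of the spread among the four values belongs to the cores themselves, a difference that no single-change pair here isolates.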